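A few compounds are considered here, and "the series" means these few. Any claim that something is new, unique, unknown or untested is made for them only; others in the source may bear on it.

In this study two compounds of the shared core have been measured so far. Compound 1, `CC(C)CCn1ccc(OCc2ccccc2)c(C#N)c1=O`, gives in a functional assay on CHO cells for positive allosteric modulation of metabotropic glutamate receptor 2 (Homo sapiens), with a stated time of 30 min (a higher number here means a larger maximal response, a lower number a smaller maximal response), a largest response of 173%. Compound 2, `CCCCn1ccc(N2CCC(c3ccccc3)CC2)c(C#N)c1=O`, gives in this assay a largest response of 309%. For the measured compounds named here, of the two numbers, compound 2 stands highest, and its only neighbour compound 1 lies lower by a gap that exceeds the usual scatter of the measurement. Compound 3, `N#Cc1c(N2CCC(c3ccccc3)CC2)ccn(CCCC(F)(F)F)c1=O`, has not yet been tested. It differs from compound 2 in a single place: trifluoromethyl in place of methyl on a saturated chain carbon, three bonds along the chain from an aromatic nitrogen. Going by the values given here, no measured pair in this set shows what this change does to the largest response, so its direction is open. For compound 3 a small step in this assay, downward if anything and possibly not beyond the scatter, is expected: a number 29 percentage points lower from compound 2 to compound 3 (beyond the scatter). Compound 3 is therefore estimated to reach 280% in this assay, with a likely range from 200% to 360%.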

Compound 3, largest response reached (Emax), in percent of the reference or control that the assay uses: 302%
Compound 3: middle estimate off by 22 percentage points, on the low side; low and high end bracket the measured number.
By their numbers in this assay, from the lowest: compound 1; then compounds 3 and 2 (each within the scatter of the next).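

In this assay, for the compounds shown here, the pair of compound 2 and compound 3 gives the first direct reading at this position, a saturated chain carbon three bonds along the chain from an aromatic nitrogen: butyl to 4,4,4-trifluorobutyl gives a number 7 percentage points lower from compound 2 to compound 3 (within the scatter) on the shared core. Trifluoromethyl, with 4 heavy atoms, can therefore stand in place of methyl, with 1, without a difference in largest response that the measurement can resolve. Nothing at hand explains this result.

On these data alone, whether a longer chain, an amine or a carboxylic acid at this chain end would also give a response matching that of compound 2 remains open. Also open, as far as these compounds go, is whether the same exchange would read alike with the benzyloxy-bearing core of compound 1.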